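Cytotoxicity of Three Biaryl Amides and a Carboxymethyl Analogue

The source may hold more compounds than are shown below. What is called first, only, known or untested is meant among the compounds shown, and "the series" means these compounds.

Measured compounds:
Compound 1, `CCOC(=O)CCCCCOc1cccc(CN(C(=O)c2ccc(-c3cccc(NC(C)=O)c3)cc2)C(C)C)c1`. In an ADME assay on Raji cells (Homo sapiens) for cytotoxicity, read by CellTiter-Glo and resazurin assay, with a stated time of 72 h (on this read-out lower numbers stand for an effect already at smaller amounts and higher numbers for an effect only at larger amounts of compound), compound 1 reaches only the assay limit of > 26000 nM.
Compound 2, `CCOC(=O)CCCCCOc1cccc(CN(C(=O)c2ccc(-c3cccc(OCC(C)C)c3)cc2)C(C)C)c1`. In this assay compound 2 likewise stops at the limit of > 26000 nM.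
Compound 3, `CCOC(=O)CCCCCOc1cccc(CN(C(=O)c2ccc(-c3cc(F)cc(OC)c3)cc2)C(C)C)c1`. In this assay compound 3 also stays at the limit of > 26000 nM.

Compound 3 thus stands where all three sit, at the limit of > 26000 nM in this assay, at which 3 of the 3 values shown sit; no number is known for it. The steps a step that the two limits leave unreadable from compound 1 to compound 3 and a step that the two limits leave unreadable from compound 2 to compound 3, like a step that the two limits leave unreadable from compound 1 to compound 2, cannot be read in size. Compound 4, `CCOC(=O)CCCCCOc1cccc(CN(C(=O)c2ccc(-c3cccc(CC(=O)O)c3)cc2)C(C)C)c1`, differs by 3-(carboxymethyl)phenyl in place of 3-fluoro-5-methoxyphenyl on an aromatic carbon. Every measured change on the same aromatic carbon, in compounds 1, 2 and 3, stayed at the limit of > 26000 nM in this assay, at which 3 of the 3 values shown sit, so no readable step size exists. A step that the limit leaves unreadable from compound 3 to compound 4 is expected to mean no effect inside the tested range. Compound 4 is therefore estimated at 30000 nM, between 15000 nM and 60000 nM.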

Compound 4, half-maximal effective concentration: > 26000 nM
Compound 4: a limit, no number (the forecaster's own chance of this, stated with the estimate: 85%); the middle value does not contradict the limit.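

For the compounds shown here, compound 4 also gives only a limit, so no step among compound 1, compound 2, compound 3 and compound 4 can be read in size: the limit of > 26000 nM in this assay, at which 4 of the 4 values shown sit. On these data alone, whether these four compounds differ at all in this assay remains open.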